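The source may hold more compounds than are shown below. What is called first, only, known or untested is meant among the compounds shown, and "the series" means these compounds.

In an assay on HEK293 cells for displacement of a labelled ligand from Melanocortin receptor 4 (Homo sapiens) (on this read-out lower numbers stand for stronger inhibition and higher numbers for weaker inhibition), compound 1 `NC(COCc1ccccc1)c1cc(F)ccc1N1CCN(C(=O)CCc2ccc(Cl)cc2Cl)CC1` gives 1000 nM, compound 2 `CCC(C)[C@H](N)c1cc(C(F)(F)F)ccc1N1CCN(C(=O)CCc2ccc(Cl)cc2)CC1` gives 86 nM, and compound 3 `CC(C)C[C@H](N)c1cc(C(F)(F)F)ccc1N1CCN(C(=O)CCc2ccccc2O)CC1` gives 3300 nM. Compound 3 thus carries the highest number of the three, beyond the scatter from compound 1 and further still from compound 2. Compound 4 `COc1ccc(CCC(=O)N2CCN(c3ccc(C(F)(F)F)cc3[C@@H](N)CC(C)C)CC2)cc1` differs from compound 3 by 4-methoxyphenyl in place of 2-hydroxyphenyl on a saturated chain carbon, two bonds along the chain from a carbonyl carbon. Among the measured compounds shown here, no measured pair isolates this change. Compound 2, which also lacks the hydroxyl on this phenyl, gives 86 nM, though it differs at the amine-bearing side chain as well. A step toward lower numbers, beyond the scatter, is therefore expected: a 6.6-fold lower number from compound 3 to compound 4 (0.82 log units; beyond the scatter). In this assay compound 4 is estimated at 500 nM, with a range from 150 nM to 2000 nM.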

Compound 4, inhibition constant: 350 nM
Compound 4: the middle estimate sits 1.4-fold (0.15 log units) above what was measured; low and high end bracket the measured number.
By their numbers in this assay, from the lowest: compound 2; then compound 4; then compound 1; then compound 3.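

In this assay, among the compounds shown here, the side chain and the rest of the core stay fixed, and 4-methoxyphenyl in place of 2-hydroxyphenyl gives a 9.4-fold lower number from compound 3 to compound 4 (0.97 log units; beyond the scatter) as the first step that isolates one place. The substituted phenyl on this saturated chain carbon therefore moves the number by itself, beyond the scatter. Nothing at hand explains this step.

The step changes both the place of the oxygen and hydroxyl versus methoxy, so the two remain unseparated. Compounds carrying 2-methoxyphenyl, 4-hydroxyphenyl or unsubstituted phenyl at this position would tell them apart.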